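A few compounds are considered here, and "the series" means these few. Any claim that something is new, unique, unknown or untested is made for them only; others in the source may bear on it.

Measured so far:
compound 1, `CCc1cc(Nc2nc(N[C@@H](C)c3ccc(F)cc3)nc3cc(F)ccc23)n[nH]1`: 100 nM
compound 2, `CCc1cc(Nc2nc(N[C@@H](C)c3cccc(F)c3)nc3ccccc23)n[nH]1`: 340 nM

In an assay on isolated protein for inhibition of G protein-coupled receptor kinase 6 (Homo sapiens), read by scintillation counting, radiometric assay and 33P incorporation, with a stated time of 80 min, in the presence of a further agent that is not named here (a lower number here means a stronger inhibitor, a higher number a weaker inhibitor), compound 1 gives 100 nM, while compound 2 gives 340 nM, so compound 2 stands with the higher of the two numbers. The two compounds differ in more than one place, so nothing is drawn from that gap. The next compound, compound 3 `CCc1cc(Nc2nc(NCc3ccc(F)cc3)nc3ccccc23)n[nH]1`, differs from compound 2 by 4-fluorobenzyl in place of 1-(3-fluorophenyl)ethyl on a nitrogen on an aromatic ring. Going by the values given here, with no single-point step known, the direction is uncertain; the stereocentre is lost, and a modest rise in the number is expected, a 2.1-fold higher number from compound 2 to compound 3 (0.31 log units; beyond the scatter), near or a little beyond the scatter. Compound 3 is therefore expected at 700 nM, between 200 nM and 2500 nM.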

Compound 3, half-maximal inhibitory concentration: 250 nM
Beside the measured number, compound 3's estimate is 2.8-fold (0.45 log units) above it; the measured number falls inside the stated range.
By their numbers in this assay, from the lowest: compound 1; then compounds 3 and 2 (each within the scatter of the next).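

In this assay, 4-fluorobenzyl in place of 1-(3-fluorophenyl)ethyl on this nitrogen gives a 1.4-fold lower number from compound 2 to compound 3 (0.13 log units; within the scatter), so losing the defined stereocentre here does not shift the number beyond the scatter. The two groups also differ in where the fluorine sits, and this single step cannot separate that from the loss of the stereocentre. Nothing available explains the result.

The compounds shown leave open whether a plain benzyl or a pyridylmethyl group on this nitrogen would give a similar number. They also leave open how a longer chain would read there.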